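A few compounds are considered here, and "the series" means these few. Any claim that something is new, unique, unknown or untested is made for them only; others in the source may bear on it.

Measured in a functional assay on HepG2 cells (Homo sapiens) for antiproliferative activity, read by MTT assay, with a stated time of 48 h; on this read-out higher numbers stand for weaker inhibition and lower numbers for stronger inhibition:
- compound 1 `Fc1ccc(CSc2nnc(-c3cnccn3)o2)c(F)c1`: 14400 nM
- compound 2 `Brc1ccccc1CSc1nnc(-c2cnccn2)n1-c1ccccc1`: 11600 nM

Compound 2, at 11600 nM, stands level with compound 1 within the usual scatter of this assay, so the two numbers cannot be told apart. Compound 3 `Fc1cccc(F)c1CSc1nnc(-c2cnccn2)n1-c1ccccc1`, not yet measured, differs from compound 2 in one place, on a saturated chain carbon bound to a sulfur: 2,6-difluorophenyl in place of 2-bromophenyl on a saturated chain carbon bound to a sulfur. In words, 2,6-difluorophenyl takes the place of 2-bromophenyl. Going by the values given here, no pair of measured compounds differs in just one place, so the data hold no direct guide to this change. With compound 2 at 11600 nM as the only starting point, no step beyond the scatter is expected in this assay, in either direction. The expected step is a 1.1-fold higher number from compound 2 to compound 3 (0.05 log units; within the scatter). For compound 3 the estimated value is 13000 nM, with an expected range of 5000 nM to 35000 nM.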

Compound 3, half-maximal inhibitory concentration: 22600 nM
The estimate for compound 3 lay 1.7-fold (0.24 log units) below the measured number; low and high end bracket the measured number.
By their numbers in this assay, from the lowest: compounds 2, 1 and 3 (each within the scatter of the next).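

With compound 3, this place on a saturated chain carbon bound to a sulfur gets its first direct comparison: in this assay, 2,6-difluorophenyl in place of 2-bromophenyl gives a 1.9-fold higher number from compound 2 to compound 3 (0.29 log units; within the scatter) and the pair cannot be told apart. So, on this one pair, a phenyl ring carrying two fluorines and one carrying a single bromine leave the antiproliferative read-out without a change that can be read. (No other evidence bears on this result).

As far as these compounds go, whether a methoxy group or an amine on that phenyl ring, or a longer chain in place of the saturated chain carbon, would give a step beyond the scatter stays open. From the compounds shown here alone, compound 1 differs from compound 2 and compound 3 in more than one place, and what its separate changes contribute also stays open.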